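Fluorinated variant on the saturated ring of compound 1

A few compounds are considered here, and "the series" means these few. Any claim that something is new, unique, unknown or untested is made for them only; others in the source may bear on it.

Measured so far:
- compound 1, `COc1cc(C2=NN(C(C)=O)C(c3cccc(OC)c3OC)O2)cc(OC)c1OC`: 58.2%
- compound 2, `COc1cc(C(=O)N/N=C/c2ccc(C(F)(F)F)cc2)cc(OC)c1OC`: 61.6%

In a functional assay on PC-3 cells (Homo sapiens) for antiproliferative activity, read by MTT assay, tested at 5 uM (a lower number here means a weaker effect, a higher number a stronger effect of the compound at the concentration tested), compound 1 gives 58.2%, the lower of the two numbers in hand. Compound 2 gives 61.6% in this assay, and the gap between compound 1 and compound 2 lies within the scatter, so the two stand level. Within the data shown here, compound 2 differs from compound 1 in more than one place, and no single step between them is known; only the two values themselves can be set side by side.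

Compound 3, `COc1cc(C2=NN(C(C)=O)C(c3ccc(F)c(F)c3)O2)cc(OC)c1OC`, is not yet measured. Its change from compound 1 is 3,4-difluorophenyl in place of 2,3-dimethoxyphenyl on a saturated ring carbon; the rest of the shared core is unchanged. Among the measured compounds shown here, no measured pair isolates this change, so neither the direction nor the size of the step is anchored by a known step. The expected step of a number 3.2 percentage points lower from compound 1 to compound 3 (within the scatter) is small and may stay within the scatter, with no firm direction. For compound 3 the estimate in this assay is 55%, with a range from 35% to 75%.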

Compound 3, a percentage reported as inhibition, at one concentration (the size of the read-out at that concentration, not a potency): 46.9%
Estimate against measurement, compound 3: 8.1 percentage points above; measured number inside the range.
By their numbers in this assay, from the lowest: compound 3; then compounds 1 and 2 (each within the scatter of the next).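

In this assay, among these compounds, this is the first step that differs in one place only: on the saturated ring carbon, 3,4-difluorophenyl in place of 2,3-dimethoxyphenyl gives a number 11.3 percentage points lower from compound 1 to compound 3 (beyond the scatter). The read-out at this position therefore depends on the aryl group it carries, which the two earlier values, from compounds differing in more than one place, could not show. The step covers the exchange of the whole aryl group, and nothing at hand explains it.

Still open, on these data alone, is how the step divides between the departure of the two methoxy groups, the arrival of the two fluorines and the change in their places on the aromatic ring, since one exchange alters all of these at once. An unsubstituted phenyl, a 3,4-dimethoxyphenyl or a 2,3-difluorophenyl on the same saturated ring carbon would separate these parts, while a 4-aminophenyl or a 4-carboxyphenyl there would test the position with groups of a different kind from either aryl group seen so far.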